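The source may report more compounds than this note shows. Statements on the series, on what has been measured and on what is new or still open speak of the compounds shown alone.

Measured in a functional assay on MCF7 cells (Homo sapiens) for cytotoxicity, read by MTT assay, with a stated time of 72 h; a lower number here means a stronger inhibitor, a higher number a weaker inhibitor:
- compound 1 `O=C(/C=C/c1cccc(Cl)c1Cl)Nc1cc2c(Nc3ccc(F)c(Cl)c3)ncnc2cc1O[C@H]1CCOC1`: 30100 nM
- compound 2 `COc1cc2ncnc(Nc3ccc(F)c(Cl)c3)c2cc1NC(=O)/C=C/c1ccccc1[N+](=O)[O-]`: 36500 nM

Compound 1 stands level with compound 2, as the two values lie within the scatter of each other. Compound 3 `COc1ccc(/C=C/C(=O)Nc2cc3c(Nc4ccc(F)c(Cl)c4)ncnc3cc2O[C@H]2CCOC2)c(OC)c1OC` is still unmeasured. It has 2,3,4-trimethoxyphenyl in place of 2,3-dichlorophenyl on a double-bonded chain carbon bound to a double-bonded chain carbon. Going by the values given here, no measured step covers this change, so no step beyond the scatter is expected in this assay. The estimate means a 1.2-fold lower number from compound 1 to compound 3 (0.08 log units; within the scatter), an expected step only. For compound 3 the expected value is 25000 nM, with an estimated range of 8000 nM to 70000 nM.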

Compound 3, half-maximal inhibitory concentration: 4650 nM
The estimate for compound 3 lay 5.4-fold (0.73 log units) above the measured number; measured number below the stated range.
By their numbers in this assay, from the lowest: compound 3; then compounds 1 and 2 (each within the scatter of the next).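

In this assay, going by these compounds alone, the group on the double-bonded chain carbon proves able to move the number: 2,3,4-trimethoxyphenyl in place of 2,3-dichlorophenyl gives a 6.5-fold lower number from compound 1 to compound 3 (0.81 log units; beyond the scatter) and this is the only step so far. The entering group carries three hydrogen-bond acceptors where the leaving group has none, but one step cannot show whether these matter. No measurement on hand gives a cause for the step.

On these data alone, whether all three methoxy groups are needed remains open. So does how a dimethylamino group or a carboxylic acid on that phenyl ring would compare.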